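Ethyl Gives Way to Methylamino on a Sulfonyl Sulfur

This account rests on a few compounds, and the source may have more. Where it says the series, first, only, none or still open, it means among the compounds named here.

In a physicochemical assay for solubility, measured as kinetic solubility (on this read-out lower numbers stand for lower solubility and higher numbers for higher solubility), compound 1 (`Cc1cnc(NC(=O)c2cc(Oc3cnc(C(=O)N(C)C)cn3)c3cn(C)nc3c2)cn1`) gives 192000 nM and compound 2 (`CCS(=O)(=O)c1ccc(Oc2cc(C(=O)Nc3cnc(C)cn3)cc3nn(C)cc23)cc1`) gives 69000 nM as the lower of the two numbers, a gap beyond the usual scatter. These two compounds differ in more than one place, so their gap cannot be pinned on any single group. Compound 3 (`CNS(=O)(=O)c1ccc(Oc2cc(C(=O)Nc3cnc(C)cn3)cc3nn(C)cc23)cc1`) departs from compound 2 in one place only, with methylamino in place of ethyl on a sulfonyl sulfur turning ethylsulfonyl into methylsulfamoyl. Among the compounds with values here, no measured pair shows this swap, which leaves no direct precedent to lean on. The expected step of a 1.3-fold lower number from compound 2 to compound 3 (0.10 log units; within the scatter) is small and slightly downward, with none beyond the scatter. For compound 3 the estimated value is 55000 nM with an expected range from 18000 nM to 160000 nM in this assay when the measurement arrives.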

Compound 3, solubility: 27000 nM
Estimate against measurement, compound 3: 2.0-fold (0.31 log units) above; measured number inside the range.
By their numbers in this assay, from the lowest: compound 3; then compound 2; then compound 1.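

Methylamino in place of ethyl on a sulfonyl sulfur brings a 2.6-fold lower number from compound 2 to compound 3 (0.41 log units; beyond the scatter) in this assay, so this position does respond to a change of a single group. Unlike the gap between compound 1 and compound 2, this step can be pinned on one place in the structure. The swap leaves the heavy-atom count the same and brings in one hydrogen-bond donor, but nothing at hand says what lies behind the step.

Compounds with a plain amino or a dimethylamino group on the same sulfur would be needed to tell whether the step follows the nitrogen itself or its hydrogen. From the compounds shown here alone, it also remains open whether a longer chain on the sulfonyl sulfur, such as propyl, would move the number at all.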